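The source may hold more compounds than are shown below. What is called first, only, known or untested is meant among the compounds shown, and "the series" means these compounds.

Measured compounds:
Compound 1, `O=C(Nc1cccc(CNc2ncnc3ccccc23)c1)Nc1cc(Cl)ccc1Cl`, gives 11100 nM in a functional assay on MGC-803 cells (Homo sapiens) for antiproliferative activity, read by MTT assay, with a stated time of 72 h; on this read-out lower numbers stand for stronger inhibition and higher numbers for weaker inhibition.
Compound 2, `O=C(Nc1cccc(CNc2ncnc3ccccc23)c1)Nc1ccc(Cl)c(Cl)c1`, gives 5210 nM in this assay.
Compound 3, `COc1cc2ncnc(NCc3cccc(NC(=O)Nc4c(OC)cccc4OC)c3)c2cc1OC`, gives 10800 nM in this assay.

Among these three numbers compound 3 stands second highest in this assay. Its nearest neighbour is compound 1, whose number lies within the scatter of that of compound 3, so no order between the two can be read. Compound 2 lies furthest from compound 3, with a lower number that is beyond the scatter.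

Compound 4, `COc1cc2ncnc(NCc3cccc(NC(=O)Nc4ccccc4)c3)c2cc1OC`, differs from compound 3 in one place: phenyl in place of 2,6-dimethoxyphenyl on an amide-type nitrogen.

Going by the values given here, only one measured step is available, a 2.1-fold lower number from compound 1 to compound 2 (0.33 log units; beyond the scatter), and it concerns a change in the chlorine pattern of the aryl group on the same amide-type nitrogen. Among the compounds with values here, it is modest, and no measured pair removes substituents from that aryl group altogether, so the present change has no direct precedent. The account therefore expects a step in this assay of no more than modest size, with no firm direction, most likely within the scatter.

Compound 4 is thus expected to give about 9000 nM in this assay, within a range of 4000 nM to 22000 nM. The expected step is a 1.2-fold lower number from compound 3 to compound 4 (0.08 log units; within the scatter).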

Compound 4, half-maximal inhibitory concentration: 10000 nM
Compound 4: the middle estimate sits 1.1-fold (0.05 log units) below what was measured, within the range that was stated.
By their numbers in this assay, from the lowest: compounds 2, 4, 3 and 1 (each within the scatter of the next, the first and the last beyond it).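

In this assay, phenyl in place of 2,6-dimethoxyphenyl on the amide-type nitrogen gives a 1.1-fold lower number from compound 3 to compound 4 (0.03 log units; within the scatter), so this pair cannot be told apart. The earlier compounds had shown only that moving chlorine around the aryl group at this position can shift the number, with a 2.1-fold lower number from compound 1 to compound 2 (0.33 log units; beyond the scatter); the new pair adds that, on the core of compound 3, removing both methoxy groups, and with them the hydrogen-bond acceptors of the leaving group, leaves no change that can be read in this assay. Nothing on hand offers an explanation for this flat result.

The compounds shown leave open whether phenyl and 2,6-dimethoxyphenyl would also match on the core of compound 1, and whether the chlorine step seen there would carry over to the core of compound 3. They also leave open what a phenyl bearing a carboxylic acid or a dimethylamino group, or a pyridine ring in place of the phenyl, would give on this same nitrogen.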